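The source may report more compounds than this note shows. Statements on the series, on what has been measured and on what is new or still open speak of the compounds shown alone.

Compound 1 `Nc1cc(N)c2nc(-c3ccccc3)c(Oc3ccc(Cl)c(Cl)c3)nc2c1` is one of three members of a small series that share one core and differ in the group attached at a single aromatic carbon of that core. In a functional assay on LOX IMVI cells (Homo sapiens) for inhibition, read by sulforhodamine B assay, with a stated time of 48 h (on this read-out higher numbers stand for weaker inhibition of growth and lower numbers for stronger inhibition of growth), compound 1 gives 33900 nM, the highest of the three numbers. Compound 3 `CCOC(=O)[C@H](CCC(=O)O)NC(=O)c1ccc(Oc2nc3cc(N)cc(N)c3nc2-c2ccccc2)cc1` in this assay gives 26300 nM, and that value is within the scatter of the value of compound 1. Compound 2 `COc1cc(CNc2nc3cc(N)cc(N)c3nc2-c2ccccc2)cc(OC)c1OC` in this assay gives 10500 nM, a lower number than that of compound 1 by a margin beyond the scatter.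

Compound 4 `Nc1cc(N)c2nc(-c3ccccc3)c(NCc3ccc(F)cc3)nc2c1` has not been measured. It differs from compound 1 in one place: (4-fluorobenzyl)amino in place of 3,4-dichlorophenoxy on an aromatic carbon. Among the measured compounds, compound 2 also carries a benzylamino group at that position, and it is compound 2 that gives the lowest number of the three, while the two aryloxy compounds, compound 1 and compound 3, sit close together at the higher end.

On that basis a step from compound 1 to compound 4 of a 2.3-fold lower number from compound 1 to compound 4 (0.35 log units; beyond the scatter) is expected, a downward step of modest size, near the edge of the scatter. The expected value for compound 4 in this assay is 15000 nM, with a likely range from 5000 nM to 40000 nM.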

Compound 4, concentration for total growth inhibition: 3160 nM
For compound 4 the middle estimate is 4.7-fold (0.68 log units) above the measured one; the measured number lies below the stated range.
By their numbers in this assay, from the lowest: compound 4; then compound 2; then compounds 3 and 1 (each within the scatter of the next).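

Among the compounds shown here, replacing 3,4-dichlorophenoxy with (4-fluorobenzyl)amino on this aromatic carbon, next to the ring nitrogen and ortho to a phenyl group, gives an 11-fold lower number from compound 1 to compound 4 (1.03 log units; beyond the scatter) in this assay and is the first reading of a single change at this position, since no earlier pair differed in one place only. The step is large although the two groups have the same count of heavy atoms and each holds one six-membered aromatic ring of carbon only, whereas the entering group has a hydrogen-bond donor and the leaving group has none. Nothing shown here accounts for the step, so the result stands without a stated cause.

From the compounds shown here alone, the change alters the linking atom, the spacing of the ring and the halogens together, so it remains open which of these carries the step; a 4-fluorobenzyloxy group or a (3,4-dichlorobenzyl)amino group at this carbon would begin to separate them. Also open, going by these compounds, is whether the amine hydrogen matters, which an N-methyl-N-(4-fluorobenzyl)amino group would address.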